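This account rests on a few compounds, and the source may have more. Where it says the series, first, only, none or still open, it means among the compounds named here.

Compound 1 `C#Cc1ccc(NC(=O)CCc2cccc3c2B(O)OC3)cc1`: 45000 nM
Compound 2 `COc1ccc(NC(=O)CCc2cccc3c2B(O)OC3)cc1`: 1700 nM
Compound 3 `COc1ccccc1NC(=O)CCc1cccc2c1B(O)OC2`: 430 nM

In a functional assay on HCT-116 cells (Homo sapiens) for antiproliferative activity, read by MTT assay, with a stated time of 72 h (on this read-out lower numbers stand for stronger inhibition and higher numbers for weaker inhibition), compound 3 gives 430 nM, the lowest number of the three, and compound 1 gives 45000 nM, the highest. Compound 2 and compound 1 share a core and differ by ethynyl in place of methoxy on an aromatic carbon; that change made a 26-fold higher number from compound 2 to compound 1 (1.42 log units; beyond the scatter). Compound 3 has the same atoms as compound 2 joined differently, and the difference between the two cores is not broken down here. Compound 4 `C#Cc1ccccc1NC(=O)CCc1cccc2c1B(O)OC2` has not been measured; it differs from compound 3 by ethynyl in place of methoxy on an aromatic carbon, the same kind of change, though here the place is ortho to a large group rather than para. Because a 26-fold higher number from compound 2 to compound 1 (1.42 log units; beyond the scatter) was large, a large weakening step is expected for compound 4 as well, estimated as a 19-fold higher number from compound 3 to compound 4 (1.27 log units; beyond the scatter). Compound 4 is therefore expected to give about 8000 nM in this assay.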

Compound 4, half-maximal inhibitory concentration: 1400 nM
Compound 4: the middle estimate sits 5.7-fold (0.76 log units) above what was measured; the whole stated range lies above it.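

In this assay, ethynyl in place of methoxy again gave weaker inhibition, with a 3.3-fold higher number from compound 3 to compound 4 (0.51 log units; beyond the scatter), so the direction of the change held on both cores. Its size did not hold: the same change on two cores in this assay, a 26-fold higher number (1.42 log units; beyond the scatter) from compound 2 to compound 1 and a 3.3-fold higher number (0.51 log units; beyond the scatter) from compound 3 to compound 4, 8.1-fold (0.91 log units) apart, beyond the scatter of two such steps. With only these two pairs, a step measured on one core cannot be carried over to the other as a number, but the pairs do not show what sets its size or how the change would behave on any further core.

On these data alone, it remains open how an amine or a carboxylic acid in place of methoxy would compare on these cores. As far as these compounds go, it is also open whether a longer chain at the amide would alter the size of the step.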